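Mirror-Image Partner of an Inactive Bicyclic Amide

The source may report more compounds than this note shows. Statements on the series, on what has been measured and on what is new or still open speak of the compounds shown alone.

The account concerns an assay on isolated protein for inhibition of Nicotinamide N-methyltransferase (Homo sapiens), read by luminescence, with a stated time of 20 min; a higher number here means a weaker inhibitor, a lower number a stronger inhibitor. Compound 1 `C[C@H]1Cc2cc(C(N)=O)cnc2N1` is known there only as a limit: in this assay compound 1 gives > 10000 nM, which is a limit of the assay and not a number. Compound 2 `CNc1ncc(C(N)=O)cn1` likewise reaches only a limit, giving > 10000 nM in this assay. Compound 3 `CNc1ncc(C(N)=O)c(C)c1C` also sits at a limit, with > 10000 nM in this assay. Thus (the limit of > 10000 nM in this assay, at which 3 of the 3 values shown sit), so no measured pair differs in one place and no step can be read from the numbers.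

Compound 4 `C[C@@H]1Cc2cc(C(N)=O)cnc2N1` is the unmeasured partner of compound 1. The change is the two compounds have the same atoms and bonds and differ only in configuration as drawn: 1 of 1 stereo elements differ; a stereocentre at a saturated ring carbon is drawn S in compound 1 and R in compound 4; in words, the two compounds have the same atoms and bonds and differ only in configuration as drawn: 1 of 1 stereo elements differ; a stereocentre at a saturated ring carbon is drawn S in compound 1 and R in compound 4. Among the compounds with values here, with every value shown a limit, there is no measured example of what such a change does here. The expected step that the limit leaves unreadable from compound 1 to compound 4 is none beyond the scatter. Compound 4 is therefore estimated at 20000 nM in this assay, with a range from 5000 nM to 100000 nM, and is expected most likely to be reported only as a limit again.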

Compound 4, half-maximal inhibitory concentration: 42 nM
Compound 4: middle estimate off by 480-fold (2.68 log units), on the high side; the measured number lies below the stated range.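

In this assay, inverting the stereocentre at the saturated ring carbon from S to R gives an at least 230-fold lower number from compound 1 to compound 4 (2.37 log units; beyond the scatter), so this single position decides between a compound that reaches no number and one that does. Within the data shown here, compound 4 gives 42 nM, the only value in the set that is a number and not a limit of the assay: the limit of > 10000 nM in this assay, at which 3 of the 4 values shown sit. The step can be assigned to configuration alone, because no atom or bond changes between the pair: the fact that compounds 1 and 4 differ only in the configuration as drawn

The compounds shown leave open how the R configuration fares when the methyl group on that ring carbon gives way to an ethyl group or a longer chain. They also leave open whether compound 4 would hold its value with a carboxylic acid or a nitrile in place of the amide.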